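From Chloro to Bromo on an Aromatic Carbon

A few compounds are considered here, and "the series" means these few. Any claim that something is new, unique, unknown or untested is made for them only; others in the source may bear on it.

Of the compounds shown here, two have measured values so far. In a functional assay on MCF7 cells (Homo sapiens) for antiproliferative activity, read by sulforhodamine B assay, with a stated time of 48 h (a lower number here means a stronger inhibitor, a higher number a weaker inhibitor), compound 1 (`COc1cccc(C(=O)C(O)C(Nc2ccc(F)c(Cl)c2)c2ccc(Br)cc2)c1`) gives 9.9 nM, and compound 2 (`COc1ccc(C(=O)C2OC2c2ccc(Cl)cc2)cc1`) gives 26 nM. Compound 2 therefore holds the higher of the two numbers, and the gap lies beyond the usual scatter. These two structures differ in more than one place, so their gap does not isolate any single change.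

Compound 3 (`COc1ccc(C(=O)C2OC2c2ccc(Br)cc2)cc1`) follows from compound 2 with bromo in place of chloro on an aromatic carbon, para to a large group (bromo in place of chloro on an aromatic carbon). Going by the values given here, no measured pair shows this exchange alone, so the expectation remains uncertain. In this assay, no change beyond the scatter is expected, in either direction. The estimated step is a 1.1-fold lower number from compound 2 to compound 3 (0.03 log units; within the scatter). Compound 3 is expected at 24 nM, with an estimated range from 10 nM to 58 nM.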

Compound 3, half-maximal inhibitory concentration: 13 nM
Compound 3: middle estimate off by 1.8-fold (0.27 log units), on the high side; measured number inside the range.
By their numbers in this assay, from the lowest: compounds 1, 3 and 2 (each within the scatter of the next, the first and the last beyond it).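

In this assay, going by these compounds alone, bromo in place of chloro on this aromatic carbon gives a 2.0-fold lower number from compound 2 to compound 3 (0.30 log units; within the scatter), the first step that isolates a single change. With the rest of the structure shared, compound 2 and compound 3 are not separated by this exchange, so this position holds either chloro or bromo without a change that can be told from the scatter. No measurement on hand bears on why the step has this size.

The compounds shown leave open how an amine or a carboxylic acid at this position would read in this assay. They also leave open whether the same exchange would give a similar step on the core of compound 1, which differs from compound 3 in more than one place.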